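Compound 4: another ring swap at the assay limit

A few compounds are considered here, and "the series" means these few. Any claim that something is new, unique, unknown or untested is made for them only; others in the source may bear on it.

In a functional assay on MCF7 cells (Homo sapiens) for antiproliferative activity, read by CellTiter-Glo, with a stated time of 5 days (a higher number here means a weaker inhibitor, a lower number a stronger inhibitor), compound 1 (`CC/C(=C(/c1ccc(/C=C/C(=O)O)cc1)c1ccc2nccn2c1)c1ccccc1`) gives 170 nM. Compound 2 (`CC/C(=C(/c1ccc(/C=C/C(=O)O)cc1)c1ccn2ccnc2c1)c1ccccc1`) gives > 500 nM, which is a limit and not a number. Compound 3 (`CC/C(=C(/c1ccc(/C=C/C(=O)O)cc1)c1ccn2nncc2c1)c1ccccc1`) gives > 500 nM, which is also a limit, so its true strength in this assay is not known.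

Compound 4 (`CC/C(=C(/c1ccc(/C=C/C(=O)O)cc1)c1ccc2nnnn2c1)c1ccccc1`) changes the group on a double-bonded chain carbon bound to an aromatic carbon and a double-bonded chain carbon: a group of 9 heavy atoms (5 carbon, 4 nitrogen; one five-membered aromatic ring with 4 hetero atoms, one six-membered aromatic ring with 1 hetero atom) in place of a group of 9 heavy atoms (6 carbon, 3 nitrogen; one five-membered aromatic ring with 3 hetero atoms, one six-membered aromatic ring with 1 hetero atom), on a double-bonded chain carbon bound to an aromatic carbon and a double-bonded chain carbon.

The closest evidence comes from earlier swaps of this same group. These are an at least 2.9-fold higher number from compound 1 to compound 2 (0.46 log units; beyond the scatter) and an at least 2.9-fold higher number from compound 1 to compound 3 (0.46 log units; beyond the scatter), while a step that the two limits leave unreadable from compound 2 to compound 3 cannot be sized. The first two show that this group can move the number, but only compound 1 at 170 nM gives a measured value, so one more swap promises little. The step expected is an at least 1.1-fold lower number from compound 3 to compound 4 (0.04 log units; that floor lies within the scatter), a small one, towards a lower number if it can be read at all. Compound 4 is estimated at 450 nM, with an expected range from 170 nM to 1200 nM, and a result given only as a limit would be no surprise.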

Compound 4, half-maximal inhibitory concentration: > 500 nM
Compound 4: a limit, no number; the forecaster's own chance of this, stated with the estimate: 55%; middle value at least 1.1-fold (0.04 log units) away from the limit.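

In this assay, the new group gives an at least 2.9-fold higher number from compound 1 to compound 4 (0.46 log units; beyond the scatter), so a third replacement for the group on this double-bonded chain carbon falls short, as compound 2 and compound 3 also did. Raising the count of hetero atoms in the five-membered aromatic ring to 4 brought back no measured value, while compound 2, with the same ring counts as compound 1, shows that these counts alone do not decide the outcome. The steps from compound 2 and from compound 3 to compound 4 cannot be read, because all three compounds sit at the same ceiling: the limit of > 500 nM in this assay, at which 3 of the 4 values shown sit.

Going by these compounds, how compound 2, compound 3 and compound 4 rank against one another stays open. Also open, on these data alone, is whether adding a methyl group or a chlorine atom to the group of compound 1 would match what compound 1 gives, the 170 nM measured for it.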